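Two Aryl Groups Swapped, Cytotoxicity Expected to Stay Unreadable

The source may report more compounds than this note shows. Statements on the series, on what has been measured and on what is new or still open speak of the compounds shown alone.

Three compounds have been measured in an ADME assay on RAW264.7 cells (Mus musculus) for cytotoxicity, read by MTT assay, with a stated time of 24 h, in the absence of a further agent; on this read-out higher numbers stand for weaker inhibition and lower numbers for stronger inhibition:

compound 1 `Cc1noc(CC2OC(=O)c3ccccc32)n1` gives > 40000 nM, a limit
compound 2 `O=C1OC(Cc2nc(Cc3ccccc3)no2)c2ccccc21` gives > 40000 nM, a limit
compound 3 `COCCCCOc1ccc(C(O)C2OC(=O)c3c(OC)cc(OC)cc32)cc1` gives > 40000 nM, a limit

Compound 3 therefore stands where every measured compound stands: at the limit, with no number behind it, since (the limit of > 40000 nM in this assay, at which 3 of the 3 values shown sit). Within the data shown here, the only one-place step among the measured compounds, a step that the two limits leave unreadable from compound 1 to compound 2, is a change of phenyl for hydrogen at another site, and its two limits leave its size unreadable, so nothing measured bears directly on the change at hand.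

Compound 4 `COc1cc(OC)c2c(c1)C(C(O)c1ccc(OCc3ccc(OC(F)F)cc3)cc1)OC2=O` differs from compound 3 by 4-(difluoromethoxy)phenyl in place of 3-methoxypropyl on a saturated chain carbon bound to an oxygen on an aromatic ring; cut one bond further out, the same difference reads 4-methoxybutyl to 4-(difluoromethoxy)benzyl. Among the measured compounds shown here, with every value at the limit, no step of any size can be read, and none beyond the scatter is expected in this assay in either direction. Compound 4 is therefore expected to sit at the limit as well, so that the step that the limit leaves unreadable from compound 3 to compound 4 is estimated to stay within the scatter. For compound 4 the estimate is 60000 nM, within a range from 20000 nM to 200000 nM.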

Compound 4, half-maximal inhibitory concentration: > 40000 nM
Compound 4 ended at the assay's limit (the forecaster's own chance of this, stated with the estimate: 85%); the middle value does not contradict the limit.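

Among these compounds, compound 3 and compound 4 both give a limit rather than a number, so no step between them can be read: the limit of > 40000 nM in this assay, at which 4 of the 4 values shown sit. Whether 4-(difluoromethoxy)phenyl in place of 3-methoxypropyl changes cytotoxicity at all stays open, as does the size of any step among these compounds.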